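This account rests on a few compounds, and the source may have more. Where it says the series, first, only, none or still open, it means among the compounds named here.

Measured so far in an assay on microsomes from intestinal mucosa for inhibition of acyl-CoA:cholesterol acyltransferase (Oryctolagus cuniculus); on this read-out lower numbers stand for stronger inhibition and higher numbers for weaker inhibition:
compound 1, `CCCCCCCC/C=C\CCCCCCCCNC(=O)Nc1ccccc1`: compound 1 reaches only a limit of the assay, > 5000 nM.
compound 2, `CCCCCCCC/C=C\CCCCCCCCNC(=O)Nc1cc(C)ccc1C`: compound 2 gives 4500 nM.
compound 3, `CCCCCCCC/C=C\CCCCCCCCNC(=O)Nc1ccc(F)cc1F`: compound 3 gives 4700 nM.

Compound 3 holds the higher of the two numbers measured in this assay, with compound 2 nearest; the gap between them, a 1.0-fold higher number from compound 2 to compound 3 (0.02 log units; within the scatter), is within the scatter. Compound 1 sits at the limit of > 5000 nM in this assay, at which 1 of the 3 values shown sits, so for it only a limit is known.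

Compound 4, `CCCCCCCC/C=C\CCCCCCCCNC(=O)Nc1c(C)cccc1Cl`, has not been measured. It differs from compound 3 in one place: 2-chloro-6-methylphenyl in place of 2,4-difluorophenyl on an amide-type nitrogen. The measured steps touching the same place are the swaps on the amide-type nitrogen away from phenyl, an at least 1.1-fold lower number from compound 1 to compound 2 (0.04 log units; that floor lies within the scatter) and an at least 1.0-fold lower number from compound 1 to compound 3 (0.02 log units; that floor lies within the scatter), both floors within the scatter, and the swap between the two substituted rings, a 1.0-fold higher number from compound 2 to compound 3 (0.02 log units; within the scatter). Going by the values given here, no measured step moves the number beyond the scatter, so for compound 4 no step beyond the scatter is expected either, in either direction: a 1.0-fold lower number from compound 3 to compound 4 (0.02 log units; within the scatter).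

Compound 4 is therefore estimated at 4500 nM in this assay, with a range from 2000 nM to 10000 nM.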

Compound 4, half-maximal inhibitory concentration: 180 nM
The estimate for compound 4 lay 25-fold (1.40 log units) above the measured number, and the stated range ends above it.
By their numbers in this assay, from the lowest: compound 4; then compounds 2 and 3 (each within the scatter of the next). At a limit, above all of these: compound 1.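

In this assay, the ring on the amide-type nitrogen now proves able to move the number beyond the scatter, with 2-chloro-6-methylphenyl entering: a 26-fold lower number from compound 3 to compound 4 (1.42 log units; beyond the scatter) and a 25-fold lower number from compound 2 to compound 4 (1.40 log units; beyond the scatter). The leaving 2,4-difluorophenyl and the entering 2-chloro-6-methylphenyl carry the same heavy-atom count and no hydrogen-bond donors or acceptors, so these counts do not separate them, and the data shown give no cause for the step. The step from phenyl, an at least 27-fold lower number from compound 1 to compound 4 (1.44 log units; beyond the scatter), is only a floor, set by a limit of the assay on compound 1: the limit of > 5000 nM in this assay, at which 1 of the 4 values shown sits.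

Going by these compounds, it remains open how much of the step belongs to the chlorine and how much to the methyl, as no ring here carries either one alone. Also open, on these data alone, is how an amine or a carboxylic acid on this ring would read, or a shorter chain in place of the long alkenyl chain.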